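This account rests on a few compounds, and the source may have more. Where it says the series, first, only, none or still open, it means among the compounds named here.

Measured compounds:

Compound 1, `O=C(Nc1cccc(-n2cc(-c3ccncc3)c(-c3ccc(Cl)c(O)c3)n2)c1)Nc1ccc(Cl)c(Cl)c1`, gives 785 nM in a functional assay on Hs-578T cells (Homo sapiens) for inhibition, read by sulforhodamine B assay, with a stated time of 48 h; on this read-out higher numbers stand for weaker inhibition of growth and lower numbers for stronger inhibition of growth.
Compound 2, `COc1cc(-c2nn(-c3cccc(NC(=O)c4ccc(Cl)c(C(F)(F)F)c4)c3)cc2-c2ccncc2)ccc1Cl`, gives 2170 nM in this assay.
Compound 3, `COc1cc(-c2nn(-c3cccc(NC(=O)Nc4ccc(Cl)c(C(F)(F)F)c4)c3)cc2-c2ccncc2)ccc1Cl`, gives 1320 nM in this assay.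

Compound 3 stands second highest of the three numbers: compound 2 lies a little higher and compound 1 a little lower, and both gaps are within the scatter, so the three cannot be told apart on these numbers. Within the data shown here, the only step measured between compounds that differ in one place is a 1.6-fold lower number from compound 2 to compound 3 (0.22 log units; within the scatter), a change at the carbonyl carbon, not at the ring studied here.

Compound 4, `COc1cc(-c2nn(-c3cccc(NC(=O)Nc4ccc(Cl)c(Cl)c4)c3)cc2-c2ccncc2)ccc1Cl`, has not yet been measured. It differs from compound 3 in one place: chloro in place of trifluoromethyl on an aromatic carbon. Among the measured compounds shown here, no measured pair shows this exchange of chloro for trifluoromethyl, so nothing here bears directly on it. Compound 1 carries the resulting 3,4-dichlorophenyl group, but it also differs from compound 3 elsewhere, so its value only shows that such a group sits in the same range.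

Compound 4 is therefore expected to give about 1100 nM, between 500 nM and 2500 nM, a step of a 1.2-fold lower number from compound 3 to compound 4 (0.08 log units; within the scatter) that is expected to stay within the scatter.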

Compound 4, concentration for 50% growth inhibition: 1430 nM
Compound 4: the middle estimate sits 1.3-fold (0.11 log units) below what was measured; the measured number falls inside the stated range.
By their numbers in this assay, from the lowest: compounds 1, 3, 4 and 2 (each within the scatter of the next, the first and the last beyond it).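

In this assay, the exchange of trifluoromethyl for chloro now has a measured pair (a 1.1-fold higher number from compound 3 to compound 4 (0.03 log units; within the scatter)), so on this ring the group of four heavy atoms and the single chlorine cannot be told apart. The two other steps to compound 4, (a 1.5-fold lower number from compound 2 to compound 4 (0.18 log units; within the scatter)) and (a 1.8-fold higher number from compound 1 to compound 4 (0.26 log units; within the scatter)), also stay inside the scatter, so neither the change at the carbonyl carbon nor methyl in place of hydrogen on the oxygen separates these compounds. Nothing measured here gives a reason for this flat result.

Still open, going by these compounds, is whether any group on this aromatic carbon moves the number beyond the scatter, as a nitrile, an amine or a carboxylic acid might show. Also open, on these data alone, is whether the exchange behaves the same with the free hydroxyl of compound 1.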